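Series notes: hydroxy in place of amino, compound 4

The compounds below may be only part of what the source reports. "The series", "measured", "known", "first", "only" and "open" are said of these compounds alone.

Measured so far in a functional assay on PC-3 cells (Homo sapiens) for cytotoxicity, read by MTT assay, with a stated time of 72 h; a lower number here means a stronger inhibitor, a higher number a weaker inhibitor:
Compound 1 `Cc1ccc(S(=O)(=O)c2nc3ccccc3nc2Nc2ccccc2)cc1` gives 1060 nM.
Compound 2 `Cc1ccc(S(=O)(=O)c2nc3ccccc3nc2Nc2ccc(N)cc2)cc1` gives 5000 nM.
Compound 3 `Cc1ccc(S(=O)(=O)c2nc3ccccc3nc2Nc2cccc(N)c2)cc1` gives 2000 nM.

Compound 3 sits close to compound 1 in this assay; the step of a 1.9-fold higher number from compound 1 to compound 3 (0.28 log units; within the scatter) is within the scatter, so no order between the two can be read. Against compound 2 the step of a 2.5-fold lower number from compound 2 to compound 3 (0.40 log units; beyond the scatter) is beyond the scatter, so compound 3 gives the clearly lower number of that pair. The remaining step, a 4.7-fold higher number from compound 1 to compound 2 (0.67 log units; beyond the scatter), shows that the same amino group placed on the other aromatic carbon costs more.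

Compound 4 `Cc1ccc(S(=O)(=O)c2nc3ccccc3nc2Nc2cccc(O)c2)cc1` differs from compound 3 by hydroxy in place of amino on an aromatic carbon. Going by the values given here, no measured step exchanges one polar one-heavy-atom group for another of the same kind; the steps at hand only show that adding amino at this carbon (compound 1 to compound 3) changed little, while at the other carbon (compound 1 to compound 2) it cost a modest amount. With the donor and acceptor count unchanged, the change is expected to stay within the scatter, a 1.1-fold lower number from compound 3 to compound 4 (0.05 log units; within the scatter). Compound 4 is therefore estimated at 1800 nM in this assay, within 700 nM to 4500 nM.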

Compound 4, half-maximal inhibitory concentration: 1690 nM
The estimate for compound 4 lay 1.1-fold (0.03 log units) above the measured number; measured number inside the range.
By their numbers in this assay, from the lowest: compounds 1, 4 and 3 (each within the scatter of the next); then compound 2.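

In this assay, hydroxy and amino are not told apart at this carbon, a 1.2-fold lower number from compound 3 to compound 4 (0.07 log units; within the scatter), and hydroxy in place of hydrogen also stays within the scatter, a 1.6-fold higher number from compound 1 to compound 4 (0.20 log units; within the scatter), so a second group at this carbon now gives a number that cannot be separated from that of compound 1. The 3-hydroxyphenyl group stays clearly apart from 4-aminophenyl, a 3.0-fold lower number from compound 2 to compound 4 (0.47 log units; beyond the scatter), which leaves compound 2 as the only one of the four with steps beyond the scatter to all the others. No measured data bear on the reason for these results.

Going by these compounds, it remains open whether 4-hydroxyphenyl would track 4-aminophenyl or 3-hydroxyphenyl in this assay. On these data alone, it is also open whether a larger group at this carbon, such as methoxy or a carboxylic acid, would stay within the scatter.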